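Pyrazole carboxamide series: methyl to trifluoromethyl on the core

The source may report more compounds than this note shows. Statements on the series, on what has been measured and on what is new or still open speak of the compounds shown alone.

Compound 1 `Cc1c(C(=O)NCc2cccc(C(F)(F)F)c2)cnn1-c1ccc(Cl)cc1` is the reference of this set. Within the data shown here, in a functional assay on cells for antagonist activity at C-C chemokine receptor type 1 (Homo sapiens), read by FLIPR and calcium flux (a lower number here means a stronger inhibitor, a higher number a weaker inhibitor), compound 1 gives 600 nM and is the only compound here with a number rather than a limit. Compound 2 `Cc1cccc(-n2ncc(C(=O)NCc3cccc(C(F)(F)F)c3)c2C)c1` carries a 3-methylphenyl group on the aromatic nitrogen of the shared core. In this assay compound 2 reaches only the limit > 3000 nM. Compound 3 `Cc1c(C(=O)NCc2cccc(C(F)(F)F)c2)cnn1-c1cccc(C(F)(F)F)c1` likewise reaches only the limit > 3000 nM in this assay. The two cores differ by 4-chlorophenyl in place of 3-methylphenyl on an aromatic nitrogen, and that difference goes with an at least 5.0-fold higher number from compound 1 to compound 2 (0.69 log units; beyond the scatter) and with an at least 5.0-fold higher number from compound 1 to compound 3 (0.69 log units; beyond the scatter); both steps sit on (the limit of > 3000 nM in this assay, at which 2 of the 3 values shown sit), so their full size is not known.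

Compound 4 `O=C(NCc1cccc(C(F)(F)F)c1)c1cnn(-c2ccc(Cl)cc2)c1C(F)(F)F` has not yet been measured. It differs from compound 1 by trifluoromethyl in place of methyl on an aromatic carbon. The same kind of change has been made once before, from compound 2 to compound 3 by trifluoromethyl in place of methyl on an aromatic carbon, where the trifluoromethyl entered on a six-membered aromatic ring of carbon only, meta to a large group, rather than on the five-membered aromatic ring with 2 nitrogen, next to the ring nitrogen and next to the ring atom that bears a 4-chlorophenyl group. That earlier step, a step that the two limits leave unreadable from compound 2 to compound 3, tells nothing of its direction or size.

Compound 4 is therefore expected to lie near 1000 nM in this assay, with a wide band from 300 nM to 3000 nM. The expected step of a 1.7-fold higher number from compound 1 to compound 4 (0.22 log units; within the scatter) rests only on the fact that compound 2 to compound 3 gave a step that the two limits leave unreadable from compound 2 to compound 3, which leaves the effect of this change open.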

Compound 4, half-maximal inhibitory concentration: > 3000 nM
Compound 4 was reported as a limit; the forecaster's own chance of this, stated with the estimate: 30%; at least 3.0-fold (0.47 log units) between middle value and limit.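

In this assay, trifluoromethyl in place of methyl on an aromatic carbon of the five-membered aromatic ring goes with an at least 5.0-fold higher number from compound 1 to compound 4 (0.69 log units; beyond the scatter), so on the core of compound 1 this change clearly weakens inhibition. On these data alone, compound 4 gives only a limit, > 3000 nM, and the full size of the step therefore stays unknown: the limit of > 3000 nM in this assay, at which 3 of the 4 values shown sit. The same kind of change on the six-membered aromatic ring, from compound 2 to compound 3, cannot be read, since both ends are limits, so the series shows no transfer of the effect from one core to another and this single readable step sets no rule.

As far as these compounds go, what remains open is whether any other group on this aromatic carbon, such as hydrogen, ethyl, chlorine or an amine, would give a readable number in this assay and how it would compare with the methyl of compound 1. Also open, from the compounds shown here alone, is whether trifluoromethyl on this carbon would be tolerated with another group on the ring nitrogen, such as 4-methoxyphenyl or cyclohexyl, or with a carboxylic acid in place of the trifluoromethyl on the benzyl part of the amide.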